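A few compounds are considered here, and "the series" means these few. Any claim that something is new, unique, unknown or untested is made for them only; others in the source may bear on it.

Measured compounds in this set:

compound 1 `CC(=O)SCCC(CCCCC(=O)Nc1ccccc1)SC(C)=O` with 3.2%
compound 2 `CC(=O)SCCC(CCCCC(=O)Nc1ccc(Cl)cc1)SC(C)=O` with 1.47%
compound 3 `O=C(CCCCC(CCSC(=O)c1ccccc1)SC(=O)c1ccccc1)Nc1ccccc1` with "not active" (no number reported)

All values come from a functional assay on HO8910 cells (Homo sapiens) for inhibition, read by MTT assay, with a stated time of 24 h, tested at 10 ug/mL; a higher number here means more inhibition of growth at the concentration tested, a lower number less inhibition of growth. Compound 1 and compound 2 share a core and differ by chloro in place of hydrogen on an aromatic carbon; the step of a number 1.7 percentage points lower from compound 1 to compound 2 (within the scatter) is within the scatter. Compound 3 carries a different core; the difference between the two cores is not broken down here. In this assay compound 3 is reported as "not active" (no number reported) without a number.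

Compound 4 `O=C(CCCCC(CCSC(=O)c1ccccc1)SC(=O)c1ccccc1)Nc1ccccc1Cl` is not yet measured. It differs from compound 3 by chloro in place of hydrogen on an aromatic carbon. This is the same kind of change as from compound 1 to compound 2, not the same: there the chloro sits para to a large group, here ortho to a large group. The earlier step of a number 1.7 percentage points lower from compound 1 to compound 2 (within the scatter) was within the scatter, and compound 3 gave no measurable inhibition, so a step of similar small size is expected here, resting on compound 3 being "not active" (no number reported). Compound 4 is therefore estimated at 3%, with an expected range from 0% to 12%.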

Compound 4, percent growth inhibition at one concentration: 1.33%
Compound 4: middle estimate off by 1.7 percentage points, on the high side; the range from low to high includes it.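

Among these compounds, no step from compound 3 to compound 4 can be read in this assay: compound 3 is reported as not active without a number, and compound 4 gives 1.33%. No evidence bears on this result. Going by these compounds, whether chloro has the same effect on the core of compound 3 as on the core of compound 1 stays open.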